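Adding a methyl group to the phenyl of compound 2

The compounds below may be only part of what the source reports. "The series", "measured", "known", "first", "only" and "open" are said of these compounds alone.

In a functional assay on MCF7 cells (Homo sapiens) for inhibition, read by sulforhodamine B assay, with a stated time of 48 h (on this read-out higher numbers stand for weaker inhibition of growth and lower numbers for stronger inhibition of growth), compound 1 `CC(C)(C)NCc1c(C(=O)O)nn(-c2ccc(Cl)cc2)c1-c1ccc(Cl)cc1` gives 246000 nM and compound 2 `CC(C)(C)NCc1c(C(=O)O)nn(-c2ccc(Cl)cc2)c1-c1ccccc1` gives 496000 nM within the scatter of compound 1. Compound 3 `Cc1ccc(-c2c(CNC(C)(C)C)c(C(=O)O)nn2-c2ccc(Cl)cc2)cc1` differs from compound 2 by methyl in place of hydrogen on an aromatic carbon in one place, methyl in place of hydrogen on an aromatic carbon, para to a large group. Among the compounds with values here, the one measured step that bears on it, a 2.0-fold higher number from compound 1 to compound 2 (0.30 log units; within the scatter) for hydrogen in place of chloro on an aromatic carbon, stays within the scatter. No change beyond the scatter is therefore expected in this assay for this substitution. The expected step is a 1.4-fold lower number from compound 2 to compound 3 (0.15 log units; within the scatter) and no larger. Compound 3 is expected at 350000 nM with an estimated range from 170000 nM to 700000 nM on this read-out.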

Compound 3, concentration for 50% growth inhibition: > 629000 nM
Compound 3 ended at the assay's limit; the forecaster's own chance of this, stated with the estimate: 5%; middle value at least 1.7-fold (0.25 log units) away from the limit.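

In this assay compound 3 stands at a limit of the assay and not at a number: the limit of > 629000 nM in this assay, at which 1 of the 3 values shown sits. Against hydrogen, the methyl change gives an at least 1.2-fold higher number from compound 2 to compound 3 (0.10 log units; that floor lies within the scatter), so its size stays unresolved. Methyl in place of chloro at this same place, para to a large group, gives an at least 2.5-fold higher number from compound 1 to compound 3 (0.40 log units; beyond the scatter), the first step here to clear the scatter and the first sign that the group at this position can matter. The compounds shown leave open how a methoxy group or an amine at this place would read, and how far past the limit compound 3 lies.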